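The source may report more compounds than this note shows. Statements on the series, on what has been measured and on what is new or still open speak of the compounds shown alone.

Compound 1 `Cc1c(C)c2c(c(C)c1O)CCC(C)(CC(=O)[N-][N+](C)(C)C)O2` gives 6000 nM in a functional assay (brain) for inhibition, with Rattus norvegicus as the target; on this read-out lower numbers stand for stronger inhibition and higher numbers for weaker inhibition.
Compound 2 `Cc1c(C)c2c(c(C)c1O)CC[C@@](C)(CC(=O)[N-][N+](C)(C)C)O2` gives 9000 nM in this assay.

Among the measured compounds shown here, compound 1 stands at the lower of the two numbers, but only just: the step of a 1.5-fold higher number from compound 1 to compound 2 (0.18 log units; within the scatter) lies within the scatter, and the sole distinction between the pair is the fact that one of compounds 1 and 2 is drawn with a defined configuration and the other without, at the place where they differ, so the two cannot be told apart on potency.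

Compound 3 `Cc1c(C)c2c(c(C)c1O)CCC(C)(CC[S+](C)C)O2` differs from compound 1 by a group of 4 heavy atoms (3 carbon, 1 sulfur; no ring) in place of a group of 7 heavy atoms (4 carbon, 2 nitrogen, 1 oxygen; no ring), on a saturated chain carbon bound to a saturated ring carbon. For the measured compounds named here, no measured step exchanges one side chain for another; the only step available, a 1.5-fold higher number from compound 1 to compound 2 (0.18 log units; within the scatter), concerns a drawn configuration and offers no guide to a change of this kind. Going by the values given here, with no precedent in the data, the most defensible expectation is a number near that of compound 1, with a wide range to allow for a real shift either way. Compound 3 is therefore estimated at 6000 nM, within 1500 nM to 24000 nM. That amounts to an expected step of no change at the digits printed from compound 1 to compound 3 (within the scatter).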

Compound 3, half-maximal inhibitory concentration: 2000 nM
For compound 3 the middle estimate is 3.0-fold (0.48 log units) above the measured one; low and high end bracket the measured number.
By their numbers in this assay, from the lowest: compound 3; then compounds 1 and 2 (each within the scatter of the next).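

Among the compounds shown here, compound 3 gives the first change here that goes beyond the scatter: in this assay, the side chain on the saturated chain carbon bound to a saturated ring carbon is exchanged, with a 3.0-fold lower number from compound 1 to compound 3 (0.48 log units; beyond the scatter) as the result. This shows that the number responds to the group at this place, and that a group of 4 heavy atoms containing sulfur, with a net charge of +1, can replace the larger group with no net charge without loss of inhibition, the shift being modest and towards stronger inhibition. The data offer no explanation for this shift.

The group differs in size, atoms and charge all at once, so these differences cannot be separated from one another. An amine, a carboxylic acid or a longer chain at this place would be needed to show how far the trend extends.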